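Adding Bromo to Compound 2: Expected Effect on Paw Edema

A few compounds are considered here, and "the series" means these few. Any claim that something is new, unique, unknown or untested is made for them only; others in the source may bear on it.

Measured so far:
Compound 1, `O=C(O)CNc1nc(-c2ccccc2)nc2ccc(Br)cc12`, gives 0%.
Compound 2, `C[C@H](Nc1nc(-c2ccccc2)nc2ccccc12)C(=O)O`, gives 9.3%.

Both numbers come from a functional assay on the whole organism (strain Wistar) for inhibition, with Rattus norvegicus as the target, read by paw edema, at a dose of 100 mg/kg by the oral route; on this read-out lower numbers stand for less inhibition and higher numbers for more inhibition at the one dose given (going by the name of the read-out). Compound 2 and compound 1 lie within the usual scatter of each other, so neither stands apart on what has been measured. Compound 3, `C[C@H](Nc1nc(-c2ccccc2)nc2ccc(Br)cc12)C(=O)O`, is not yet measured; it differs from compound 2 by bromo in place of hydrogen on an aromatic carbon. Going by the values given here, no comparable step between measured compounds exists, so the size of such a change is unknown here; compound 1, which also carries bromo, gives only 0%. Compound 3 is therefore expected to show no change beyond the scatter, a step of a number 3.3 percentage points lower from compound 2 to compound 3 (within the scatter). Compound 3 is estimated at 6%, between 0% and 20%.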

Compound 3, a percentage reported as inhibition, in the whole organism at one dose (the size of the read-out at that dose, not a potency): 0%
Estimate against measurement, compound 3: 6 percentage points above, within the range that was stated.
By their numbers in this assay, from the lowest: compounds 1, 3 and 2 (each within the scatter of the next).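

In this assay, going by these compounds alone, the step of a number 9.3 percentage points lower from compound 2 to compound 3 (within the scatter) is the first reading of bromo in place of hydrogen on this aromatic carbon, and it does not stand clear of the scatter. Methyl in place of hydrogen on the saturated chain carbon, read with bromo present, gives no change at the digits printed from compound 1 to compound 3 (within the scatter) and so also shows nothing beyond the scatter. Nothing measured here offers an explanation for either step.

On these data alone, whether bromo would matter in a compound with a clearly larger reading stays open. Also open, as far as these compounds go, is what a methoxy group or an amine would give on this aromatic carbon.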